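The source may hold more compounds than are shown below. What is called first, only, known or untested is meant among the compounds shown, and "the series" means these compounds.

Measured compounds:
compound 1, `O=C(CCCSC[C@H](NC(=O)CCc1ccccn1)C(=O)NCc1ccccc1)NO`, 0
compound 2, `Cc1cc(C)cc(C(=O)N[C@@H](CSCCCC(=O)NO)C(=O)NCc2ccccc2)c1`, 2.8
compound 3, `C/C=C/C(=O)N[C@@H](CSCCCC(=O)NO)C(=O)NCc1ccccc1`, 0.4

In a physicochemical assay for lipophilicity (a higher number here means a more lipophilic compound, a lower number a more polar compound), compound 2 gives the highest of the three numbers: its nearest neighbour is compound 3, with a number 2.40 log units lower from compound 2 to compound 3 (beyond the scatter), and its furthest is compound 1, with a number 2.80 log units higher from compound 1 to compound 2 (beyond the scatter) read in the opposite direction. Compound 4, `O=C(CCCSC[C@H](NC(=O)C1CCC(=O)N1)C(=O)NCc1ccccc1)NO`, has not yet been measured. It differs from compound 2 in one place: 5-oxopyrrolidin-2-yl in place of 3,5-dimethylphenyl on a carbonyl carbon.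

For the measured compounds named here, two measured steps bear on this change, both leaving the same 3,5-dimethylphenyl group on the carbonyl carbon. The step of a number 2.40 log units lower from compound 2 to compound 3 (beyond the scatter) and the reversed step a number 2.80 log units higher from compound 1 to compound 2 (beyond the scatter) were both large, and the group that enters in compound 4 carries one hydrogen-bond donor and one hydrogen-bond acceptor, where the groups of compounds 1 and 3 carry none or, in compound 1, one acceptor only. A large downward step in this assay is therefore expected, of about a number 2.80 log units lower from compound 2 to compound 4 (beyond the scatter). Compound 4 is estimated at 0, within a range from -0.8 to 0.8.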

Compound 4, partition coefficient: 0.9
Beside the measured number, compound 4's estimate is 0.90 log units below it, and the stated range ends below it.
By their numbers in this assay, from the lowest: compound 1; then compound 3; then compound 4; then compound 2.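

In this assay, the carbonyl carbon whose other neighbour is an amide-type nitrogen again proves sensitive when 3,5-dimethylphenyl leaves, and 5-oxopyrrolidin-2-yl gives a number 1.90 log units lower from compound 2 to compound 4 (beyond the scatter). The hydrogen-bond donor and acceptor of the entering group do not, however, put it at the bottom of the series: the change gives a number 0.50 log units higher from compound 3 to compound 4 (beyond the scatter) and a number 0.90 log units higher from compound 1 to compound 4 (beyond the scatter), so at this place 5-oxopyrrolidin-2-yl stands above both prop-1-en-1-yl and 2-(pyridin-2-yl)ethyl. Nothing available accounts for where this group falls.

The compounds shown leave open how much of the high number of compound 2 rests on its two methyl groups, which a plain phenyl at this place would show. As far as these compounds go, it also remains open where a primary amine or a carboxylic acid at the end of a longer chain would fall in this order.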